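This account rests on a few compounds, and the source may have more. Where it says the series, first, only, none or still open, it means among the compounds named here.

In a functional assay on CCRF-CEM cells (Homo sapiens) for inhibition (on this read-out higher numbers stand for weaker inhibition and lower numbers for stronger inhibition), the compounds examined so far have yielded no exact number. Compound 1 (`O=C(CCCCC[S+]([O-])c1ccccc1)NO`) gives > 25000 nM, which is a limit of the assay. Compound 3 (`O=C(CCCCCSc1ccc(Cl)cc1)NO`) gives > 25000 nM, which is also a limit. For compound 2 (`CN(C)c1ccc2sc(/C=C/C=C/C(=O)NO)cc2c1`) the entry reads "not determined" (no result reported). Compound 1 thus stands at the limit of > 25000 nM in this assay, at which 2 of the 3 values shown sit, and there is no exact value from which to count.

Compound 4 (`O=C(CCCCC[S+]([O-])c1ccc(Cl)cc1)NO`) has not yet been measured. It departs from compound 1 by a single change: chloro in place of hydrogen on an aromatic carbon. Among the compounds with values here, no step between measured compounds is available to size this change, so the expectation is a cautious one: no step beyond the usual scatter, in either direction, and a good chance that compound 4 also reaches the limit. The expected step, a number no higher from compound 1 to compound 4 (the limit leaves the size open), is therefore small. For compound 4 the estimated value in this assay is 25000 nM, with an expected range of 8000 nM to 50000 nM.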

Compound 4, half-maximal inhibitory concentration: 2600 nM
The estimate for compound 4 lay 9.6-fold (0.98 log units) above the measured number; measured number outside the range, below it.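

In this assay, within the data shown here, chloro in place of hydrogen on the aromatic carbon para to a large group gives an at least 9.6-fold lower number from compound 1 to compound 4 (0.98 log units; beyond the scatter), and compound 4 is the first compound here to yield an exact number. The chloro group is not enough on its own, since compound 3, which also carries it on its aromatic ring, gives > 25000 nM, and this is a limit. The step has an open size, with only its lower end fixed, because compound 1 stands at a limit: the limit of > 25000 nM in this assay, at which 2 of the 4 values shown sit.

The compounds shown leave open whether fluoro, methoxy or an amine in the same place would lower the number as chloro does. They also leave open whether a longer chain would keep the gain seen with compound 4.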